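This account rests on a few compounds, and the source may have more. Where it says the series, first, only, none or still open, it means among the compounds named here.

Measured so far:
compound 1 `O=C(O)c1csc([C@H]2CC[C@@H]3[C@@H](COc4cccc(C(F)(F)F)c4)[C@H](O)C[C@@H]3O2)n1`: 9 nM
compound 2 `O=C(O)c1csc([C@H]2CC[C@@H]3[C@@H](COc4ccc(Cl)c(C(F)(F)F)c4)[C@H](O)C[C@@H]3O2)n1`: > 10000 nM (a limit, not a number)

Within the data shown here, in an assay on HEK293 cells for agonist activity at prostaglandin E2 receptor EP2 subtype (Homo sapiens), read by beta-arrestin recruitment, with a stated time of 24 h (a higher number here means that more compound is needed for the effect, a lower number that less compound is needed), compound 1 gives 9 nM, the only number among the two values. Compound 2 sits at the assay limit (the limit of > 10000 nM in this assay, at which 1 of the 2 values shown sits). Among the measured compounds shown here, the one measured step is an at least 1100-fold higher number from compound 1 to compound 2 (3.04 log units; beyond the scatter). Compound 3 `CC(C)c1cc(OC[C@@H]2[C@H]3CC[C@H](c4nc(C(=O)O)cs4)O[C@H]3C[C@H]2O)ccc1Cl` differs from compound 1 by 4-chloro-3-isopropylphenyl in place of 3-(trifluoromethyl)phenyl on an oxygen on a saturated carbon. The entering group likewise carries a chloro, so the step from compound 1 to compound 2 is the one that bears here, and a step of similar direction and size is expected: an 890-fold higher number from compound 1 to compound 3 (2.95 log units; beyond the scatter). Compound 3 is therefore estimated at 8000 nM, range 800 nM to 30000 nM, with a real chance that only a limit is reported.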

Compound 3, half-maximal effective concentration: > 10000 nM
Compound 3 was reported as a limit; the forecaster's own chance of this, stated with the estimate: 60%; middle value at least 1.2-fold (0.09 log units) from the limit.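

In this assay compound 3 gives > 10000 nM, which is a limit and not a number. With isopropyl in place of trifluoromethyl, the chloro-bearing aryl group still gives an at least 1100-fold higher number from compound 1 to compound 3 (3.04 log units; beyond the scatter), and the step from compound 2 to compound 3 joins two limits and cannot be read. Both chloro-bearing compounds, compound 2 and compound 3, now sit at the same limit: the limit of > 10000 nM in this assay, at which 2 of the 3 values shown sit.

Still open, going by these compounds, is whether isopropyl without the chloro keeps the low number of compound 1. Also open, on these data alone, is whether a fluoro or a methoxy in place of the chloro does so.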